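From Hydrogen to Trifluoromethyl on an Aromatic Carbon

This account rests on a few compounds, and the source may have more. Where it says the series, first, only, none or still open, it means among the compounds named here.

- Compound 1 `O=C1C=CC2(C=C1)OCC(=O)N2c1nc(-c2ccc3ccccc3c2)nn1-c1ccc(Cl)cc1`: 400 nM
- Compound 2 `O=C1C=CC2(C=C1)OCC(=O)N2c1nc(-c2ccc3ccccc3c2)nn1-c1ccccc1`: 140 nM

In a functional assay on A549 cells (Homo sapiens) for antiproliferative activity, with a stated time of 5 days (a lower number here means a stronger inhibitor, a higher number a weaker inhibitor), compound 2 has the lower of the two numbers, at 140 nM, which makes it the stronger inhibitor of the pair. Compound 3 `O=C1C=CC2(C=C1)OCC(=O)N2c1nc(-c2ccc3ccccc3c2)nn1-c1ccc(C(F)(F)F)cc1` differs from compound 2 by one change: trifluoromethyl in place of hydrogen on an aromatic carbon. That is, trifluoromethyl in place of hydrogen on an aromatic carbon, para to a large group.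

For the measured compounds named here, only one measured step bears on this change: a 2.9-fold lower number from compound 1 to compound 2 (0.46 log units; beyond the scatter). It is modest, and it shows hydrogen giving a lower number than chloro. Going by the values given here, no trifluoromethyl compound has been measured, so this single comparison is a loose guide. Read in reverse, it suggests that a group replacing hydrogen may raise the number by a similar modest amount. The expected change is a 2.7-fold higher number from compound 2 to compound 3 (0.43 log units; beyond the scatter). For compound 3 the estimated value is 380 nM, with an expected range of 150 nM to 950 nM.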

Compound 3, half-maximal inhibitory concentration: 460 nM
Compound 3: the middle estimate sits 1.2-fold (0.08 log units) below what was measured; the measured number falls inside the stated range.
By their numbers in this assay, from the lowest: compound 2; then compounds 1 and 3 (each within the scatter of the next).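

In this assay, trifluoromethyl in place of hydrogen on this phenyl ring gives a 3.3-fold higher number from compound 2 to compound 3 (0.52 log units; beyond the scatter). That is a second group, after chloro, that comes with a higher number than hydrogen at this place, so the earlier step no longer rests on chloro alone. Trifluoromethyl in place of chloro gives a 1.2-fold higher number from compound 1 to compound 3 (0.06 log units; within the scatter), which leaves the two groups indistinguishable here, and no measurement at hand offers a reason for this.

Among these three compounds, hydrogen alone stands apart, but two groups are a thin basis for a rule about this position. Going by these compounds, it remains open whether an amine, a methoxy group or a carboxylic acid at the same place would fall with chloro and trifluoromethyl or match hydrogen.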